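The source may report more compounds than this note shows. Statements on the series, on what has been measured and on what is new or still open speak of the compounds shown alone.

Compound 1 `OC[C@H]1O[C@@H](n2cnc3c(NCc4cccc(F)c4)ncnc32)[C@H](O)[C@@H]1O`: 920 nM
Compound 2 `OC[C@H]1O[C@@H](n2cnc3c(NCc4ccc(F)cc4)ncnc32)[C@H](O)[C@@H]1O`: 1200 nM
Compound 3 `OC[C@H]1O[C@@H](n2cnc3c(NCc4ccc(Br)cc4)ncnc32)[C@H](O)[C@@H]1O`: 47400 nM

These three numbers come from a functional assay on HL-60 cells (Homo sapiens) for antiproliferative activity, with a stated time of 72 h; on this read-out higher numbers stand for weaker inhibition and lower numbers for stronger inhibition. Compound 1 stands lowest of the three: compound 2 sits close to it, with a 1.3-fold higher number from compound 1 to compound 2 (0.12 log units; within the scatter), whereas compound 3 lies far off, with a 52-fold higher number from compound 1 to compound 3 (1.71 log units; beyond the scatter). Compound 4 `Cc1ccc(CNc2ncnc3c2ncn3[C@@H]2O[C@H](CO)[C@@H](O)[C@H]2O)cc1` has not been measured. It differs from compound 1 in one place: 4-methylphenyl in place of 3-fluorophenyl on a saturated chain carbon bound to a nitrogen on an aromatic ring. Among the compounds with values here, two measured steps bear on this place. Moving the fluorine on the phenyl ring left the number unchanged within the scatter, but exchanging the halogen gave a 40-fold higher number from compound 2 to compound 3 (1.60 log units; beyond the scatter), a large loss. Within the data shown here, a methyl group in that position has no measured counterpart, so the expectation is uncertain, but a weakening is expected: a 6.5-fold higher number from compound 1 to compound 4 (0.81 log units; beyond the scatter). Compound 4 is estimated at 6000 nM in this assay, within 1500 nM to 30000 nM.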

Compound 4, half-maximal inhibitory concentration: > 166000 nM
Compound 4: no number, only a limit; the forecaster's own chance of this, stated with the estimate: 5%; middle value at least 27-fold (1.44 log units) from the limit.
By their numbers in this assay, from the lowest: compounds 1 and 2 (each within the scatter of the next); then compound 3. At a limit, above all of these: compound 4.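

In this assay compound 4 gives no number, only a limit: the limit of > 166000 nM in this assay, at which 1 of the 4 values shown sits. Against the fluoro compounds the change is large, with an at least 180-fold higher number from compound 1 to compound 4 (2.25 log units; beyond the scatter) and an at least 130-fold higher number from compound 2 to compound 4 (2.14 log units; beyond the scatter), so this place tolerates 4-methylphenyl far less well than either fluorophenyl. The loss seen with 4-bromophenyl is also not the end of the range, with an at least 3.5-fold higher number from compound 3 to compound 4 (0.54 log units; beyond the scatter).

The compounds shown leave open how far compound 4 truly lies, since each of its steps is only a minimum. They also leave open whether 3-methylphenyl or 4-methoxyphenyl would stay close to compound 1.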